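Removing the chloro from compound 1: an expectation

The source may report more compounds than this note shows. Statements on the series, on what has been measured and on what is new or still open speak of the compounds shown alone.

Three compounds share one core and were tested in an assay on isolated protein for displacement of a labelled ligand from metabotropic glutamate receptor 5 (Homo sapiens), with a stated time of 60 min, tested at 1 uM; a lower number here means less inhibition, a higher number more inhibition at the concentration tested (going by the name of the read-out). Compound 1 `COc1ccc2ncc(S(=O)(=O)c3ccc(OC)c(Cl)c3)c(N3CCC(C)CC3)c2c1` gives 21%, the lowest of the three numbers. Compound 2 `CC1CCN(c2c(S(=O)(=O)c3ccc(Cl)c(Cl)c3)cnc3ccc(Cl)cc23)CC1` gives 86%, and compound 3 `COc1ccc(S(=O)(=O)c2cnc3ccc(F)cc3c2N2CCC(C)CC2)cc1Cl` gives 82%. Going by the values given here, the one measured step, a number 61 percentage points higher from compound 1 to compound 3 (beyond the scatter), is large and beyond the scatter, but it concerns the group on the core, not the sulfonyl-bound ring.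

Compound 4 `COc1ccc(S(=O)(=O)c2cnc3ccc(OC)cc3c2N2CCC(C)CC2)cc1` has not been measured. It differs from compound 1 as follows: hydrogen in place of chloro on an aromatic carbon; cut one bond further out, the change reads 3-chloro-4-methoxyphenyl to 4-methoxyphenyl. Among the compounds with values here, no measured step touches this ring, so the direction can only be guessed from where compound 1 stands. Since compound 1 already sits low, the change from chloro to hydrogen is expected to leave the number low or lower it a little, a step of a number 7 percentage points lower from compound 1 to compound 4 (within the scatter). Compound 4 is therefore estimated at 14%, between 2% and 35%.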

Compound 4, a percentage reported as inhibition, at one concentration (the size of the read-out at that concentration, not a potency): 41%
Compound 4: the middle estimate sits 27 percentage points below what was measured, outside the stated range (above it).
By their numbers in this assay, from the lowest: compound 1; then compound 4; then compounds 3 and 2 (each within the scatter of the next).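

Taking the chloro off the ring gives a number 20 percentage points higher from compound 1 to compound 4 (beyond the scatter) in this assay, the first measured step at this position, ortho to a methoxy group. The chloro is thus not required for the inhibition seen with a methoxy group on the core, and the plain 4-methoxyphenyl ring reads higher than the 3-chloro-4-methoxyphenyl ring; this step is modest, whereas the change on the core in a number 61 percentage points higher from compound 1 to compound 3 (beyond the scatter) is large. Nothing measured on these compounds offers a reason for the rise.

On these data alone, the step is known only with the methoxy group on the core, so whether removing the chloro does the same alongside the fluoro of compound 3 stays open. The compounds shown also leave open what a nitrile or an amine would give at this position.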